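Swapping fluoro for trifluoromethyl on a second core

A few compounds are considered here, and "the series" means these few. Any claim that something is new, unique, unknown or untested is made for them only; others in the source may bear on it.

In a functional assay on HL-60 cells (Homo sapiens) for cytotoxicity, read by MTT assay, with a stated time of 4 days (on this read-out higher numbers stand for weaker inhibition and lower numbers for stronger inhibition), compound 1 `C=C1C[C@]23C[C@@]1(O)CC[C@H]2c1ccc(O)c(C)c1[C@@H]3Cn1cc(-c2ccc(C(F)(F)F)cc2)nn1` gives 8950 nM. Compound 2 `C=C1C[C@]23C[C@@]1(O)CC[C@H]2c1ccc(O)c(C)c1[C@@H]3Cn1cc(-c2ccc(F)cc2)nn1` is reported in this assay only as a limit, > 20000 nM. Going from compound 2 to compound 1 the change is trifluoromethyl in place of fluoro on an aromatic carbon, and it brings an at least 2.2-fold lower number from compound 2 to compound 1 (0.34 log units; beyond the scatter); the size of that step is known only as a lower bound because of the limit of > 20000 nM in this assay, at which 2 of the 3 values shown sit. Compound 3 `C=C1C[C@]23C[C@@]1(O)CC[C@@H]2c1cccc(C)c1[C@@H]3Cn1cc(-c2ccc(F)cc2)nn1` carries the same 4-fluorophenyl group as compound 2 but sits on a different core; the difference between the two cores is not broken down here. In this assay compound 3 likewise gives only a limit, > 20000 nM. Compound 4 `C=C1C[C@]23C[C@@]1(O)CC[C@@H]2c1cccc(C)c1[C@@H]3Cn1cc(-c2ccc(C(F)(F)F)cc2)nn1` is the not yet measured partner of compound 3, carrying (trifluoromethyl in place of fluoro on an aromatic carbon); the place of the change is the same as in the pair compound 2 and compound 1, so it is the same change made on the other core. The earlier step rests on a limit and the two cores are not compared in detail, so the step expected from compound 3 to compound 4 is set at a similar size, an at least 1.4-fold lower number from compound 3 to compound 4 (0.15 log units; that floor lies within the scatter). On that basis compound 4 is estimated at 14000 nM in this assay, with an expected range from 6000 nM to 30000 nM, and a real chance that the measurement again comes back only as a limit.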

Compound 4, half-maximal inhibitory concentration: > 20000 nM
Compound 4 ended at the assay's limit (the forecaster's own chance of this, stated with the estimate: 40%); middle value at least 1.4-fold (0.15 log units) away from the limit.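

Compound 3 and compound 4 both stop at a limit in this assay, so no step can be read between them, and the size of the change from fluoro to trifluoromethyl on this core stays unknown: the limit of > 20000 nM in this assay, at which 3 of the 4 values shown sit.

The compounds shown leave open whether the change that lowered the number from compound 2 to compound 1 has any effect on the core of compound 3 and compound 4.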